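Adding one fluoro to a weak growth inhibitor

The source may report more compounds than this note shows. Statements on the series, on what has been measured and on what is new or still open speak of the compounds shown alone.

- compound 1 `c1ccc(-c2ccc(-c3ccc(-c4nc5ccccc5[nH]4)cc3)cc2)cc1` gives 39200 nM
- compound 2 `COc1cc(-c2ccc(-c3ccc(-c4nc5cc(C)ccc5[nH]4)cc3)cc2)cc(OC)c1OC` gives 170 nM

Read in a functional assay on MCF7 cells (Homo sapiens) for inhibition, read by sulforhodamine B assay (a lower number here means a stronger inhibitor of growth, a higher number a weaker inhibitor of growth), compound 1 stands highest of the two at 39200 nM and is the weaker inhibitor of growth, while compound 2 sits at 170 nM (a gap well beyond the usual scatter of repeated measurements). Compound 3 (`Fc1ccc(-c2ccc(-c3ccc(-c4nc5ccccc5[nH]4)cc3)cc2)cc1`) keeps the core of compound 1 and alters a single place. The change sits para to a large group, so that phenyl becomes 4-fluorophenyl (fluoro in place of hydrogen on an aromatic carbon).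

Among the measured compounds shown here, no pair of measured compounds shows this change alone, and compounds 1 and 2 differ in more than one place, so their gap cannot size it. The expectation is therefore modest: a small move toward a lower number, possibly no larger than the scatter, and nothing close to the gap that separates the two measured compounds. The estimated step is a 1.8-fold lower number from compound 1 to compound 3 (0.25 log units; within the scatter) (small, and toward stronger inhibition). The estimated value for compound 3 is 22000 nM (range 7000 nM to 50000 nM).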

Compound 3, concentration for 50% growth inhibition: 36200 nM
Beside the measured number, compound 3's estimate is 1.6-fold (0.22 log units) below it, and the stated range covers the measured number.
By their numbers in this assay, from the lowest: compound 2; then compounds 3 and 1 (each within the scatter of the next).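

In this assay, among the compounds shown here, the step from hydrogen to fluoro, which turns phenyl into 4-fluorophenyl, comes to a 1.1-fold lower number from compound 1 to compound 3 (0.03 log units; within the scatter) and so gives the first direct reading of this single change at this position. At this place on the core of compound 1, one fluorine atom on an aromatic carbon leaves the two compounds indistinguishable in this measurement, so the swap alone has no effect that can be told apart from ordinary variation between repeated measurements. Nothing available here offers an explanation for this result, and the two numbers by themselves show only its size, not what lies behind it.

This single pair says nothing about what a different kind of group at the same place, such as an amine or a carboxylic acid, would do to growth inhibition. It also leaves open whether fluoro in place of hydrogen would read the same way on a core that carries other groups, since this one step was read on the core of compound 1 alone.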